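Aryl for Cyclopropylmethyl on the Saturated Ring Carbon

The source may report more compounds than this note shows. Statements on the series, on what has been measured and on what is new or still open speak of the compounds shown alone.

Measured so far:
Compound 1, `CN1CC(=O)N(C)c2cnc(Nc3ccc(S(N)(=O)=O)cc3)nc21`, 495 nM
Compound 2, `CN1C(=O)C(CC2CC2)N(C)c2nc(Nc3ccc(S(N)(=O)=O)cc3)ncc21`, 211 nM

In an assay on Sf9 cells for inhibition of serine/threonine-protein kinase 4 (Homo sapiens), read by luminescence and ADP-Glo, with a stated time of 1 h, in the presence of a further agent that is not named here (a higher number here means a weaker inhibitor, a lower number a stronger inhibitor), compound 1 gives 495 nM. Going by the values given here, compound 2 carries a cyclopropylmethyl on a saturated ring carbon of the shared core, and in this assay compound 2 gives 211 nM, the lowest of the two numbers recorded; the only step measured, a 2.3-fold lower number from compound 1 to compound 2 (0.37 log units; beyond the scatter), is modest but beyond the scatter.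

Compound 3, `CN1C(=O)C(c2cccc(F)c2)N(C)c2nc(Nc3ccc(S(N)(=O)=O)cc3)ncc21`, follows from compound 2 by 3-fluorophenyl in place of cyclopropylmethyl on a saturated ring carbon. Among the compounds with values here, the one measured step bears on it only indirectly: it shows that filling this position with a small carbon group lowered the number, but nothing recorded tells how an aromatic group at the same position behaves. The expected step is therefore small and uncertain, and compound 3 is estimated at 170 nM, with a range from 50 nM to 600 nM, meaning an expected change of a 1.2-fold lower number from compound 2 to compound 3 (0.09 log units; within the scatter).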

Compound 3, half-maximal inhibitory concentration: 134 nM
Compound 3: the middle estimate sits 1.3-fold (0.10 log units) above what was measured; the measured number falls inside the stated range.
By their numbers in this assay, from the lowest: compounds 3 and 2 (each within the scatter of the next); then compound 1.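

The saturated ring carbon accepts an aromatic group as well as a small carbon group: in this assay, the change to 3-fluorophenyl gives a 1.6-fold lower number from compound 2 to compound 3 (0.20 log units; within the scatter) and so does not separate it from cyclopropylmethyl, although it has 7 heavy atoms against 4. Measured against hydrogen at the same carbon, 3-fluorophenyl gives a 3.7-fold lower number from compound 1 to compound 3 (0.57 log units; beyond the scatter) and so places a second, quite different group beyond the scatter from compound 1. Nothing available explains this tolerance of two such different groups.

On these data alone, it remains open whether the fluorine plays any part, a question that plain phenyl would address. Also open, as far as these compounds go, is how a longer chain, or a group carrying an amine or a carboxylic acid, would behave on this carbon.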